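Phenyl for pyridin-3-yl on the thioether side chain

This account rests on a few compounds, and the source may have more. Where it says the series, first, only, none or still open, it means among the compounds named here.

Of the compounds shown here, three have been measured so far: compound 1 `CC(Sc1nc2c(cnn2C)c(=O)n1-c1ccc(CO)cc1)c1ccccc1` with 1000 nM in an assay on isolated protein for inhibition of Retinaldehyde dehydrogenase 3 (Homo sapiens) (on this read-out higher numbers stand for weaker inhibition and lower numbers for stronger inhibition), compound 2 `CCC(Sc1nc2c(cnn2C)c(=O)n1-c1ccccc1)c1ccccc1` with 119 nM, and compound 3 `CC(Sc1nc2c(cnn2C)c(=O)n1-c1ccccc1)c1cccnc1` with 95 nM.

Compound 3 gives the lowest number of the three in this assay, yet the gap to compound 2 is within the scatter, while compound 1 sits clearly higher. Compound 4 `CC(Sc1nc2c(cnn2C)c(=O)n1-c1ccccc1)c1ccccc1` differs from compound 3 by phenyl in place of pyridin-3-yl on a saturated chain carbon bound to a saturated chain carbon and a sulfur. For the measured compounds named here, only one measured step touches this region: a 1.3-fold lower number from compound 2 to compound 3 (0.10 log units; within the scatter), and that step also changed the chain length. No listed step removes the ring nitrogen alone. Compound 4 is therefore expected to land close to compound 3, with a step of a 1.4-fold higher number from compound 3 to compound 4 (0.14 log units; within the scatter), at an estimated 130 nM (range 50 nM to 350 nM).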

Compound 4, half-maximal inhibitory concentration: 73 nM
Compound 4: middle estimate off by 1.8-fold (0.25 log units), on the high side; low and high end bracket the measured number.
By their numbers in this assay, from the lowest: compounds 4, 3 and 2 (each within the scatter of the next); then compound 1.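

In this assay, phenyl in place of pyridin-3-yl gives a 1.3-fold lower number from compound 3 to compound 4 (0.11 log units; within the scatter) and hydrogen in place of methyl on the side chain gives a 1.6-fold lower number from compound 2 to compound 4 (0.21 log units; within the scatter) so neither the ring nitrogen nor the extra methyl shifts the number beyond the scatter. Hydrogen in place of hydroxymethyl on an aromatic carbon gives a 14-fold lower number from compound 1 to compound 4 (1.14 log units; beyond the scatter) and this is the only large step among these compounds. No measured evidence explains any of these steps.

Still open, going by these compounds, is how an amine or a carboxylic acid on that aromatic carbon would read. Also open, on these data alone, is whether a longer chain or a cyclopropyl group on the sulfur-bearing carbon would stay within the scatter of compound 4.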